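Swapping a chloromethyl for a vinyl on two related cores

The source may hold more compounds than are shown below. What is called first, only, known or untested is meant among the compounds shown, and "the series" means these compounds.

Compound 1 `O=C(CCl)Nc1ccc(Cn2nc(-c3ccc(Oc4ccccc4)cc3)cc2CO)cc1` carries a chloromethyl group on a carbonyl carbon; in a functional assay on Rec1 cells (Homo sapiens) for inhibition, read by luminescence and CellTiter-Glo, with a stated time of 72 h (on this read-out higher numbers stand for weaker inhibition and lower numbers for stronger inhibition), compound 1 gives 400 nM. Compound 2 `C=CC(=O)Nc1ccc(Cn2nc(-c3ccc(Oc4ccccc4)cc3)cc2CO)cc1` differs only by vinyl in place of chloromethyl on a carbonyl carbon, and compound 2 gives 3500 nM, so the change made an 8.8-fold higher number from compound 1 to compound 2 (0.94 log units; beyond the scatter). Compound 3 `O=C(CCl)Nc1cccc(Cn2nc(-c3ccc(Oc4ccccc4)cc3)cc2C(=O)O)c1` rests on a different core; how the two cores differ is not broken down here. Compound 3 gives 7100 nM in this assay, the highest of the three numbers. Compound 4 `C=CC(=O)Nc1cccc(Cn2nc(-c3ccc(Oc4ccccc4)cc3)cc2C(=O)O)c1` is to compound 3 what compound 2 is to compound 1: vinyl in place of chloromethyl on a carbonyl carbon, at the same place. Because the earlier step of an 8.8-fold higher number from compound 1 to compound 2 (0.94 log units; beyond the scatter) went toward weaker inhibition, a step of similar direction is expected here, a 5.6-fold higher number from compound 3 to compound 4 (0.75 log units; beyond the scatter), although the different core keeps this uncertain. Compound 4 is therefore estimated at 40000 nM, with a likely range from 10000 nM to 150000 nM.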

Compound 4, half-maximal inhibitory concentration: 33100 nM
For compound 4 the middle estimate is 1.2-fold (0.08 log units) above the measured one, within the range that was stated.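

Replacing chloromethyl with vinyl on the carbonyl carbon again moved the number in this assay toward weaker inhibition, with a 4.7-fold higher number from compound 3 to compound 4 (0.67 log units; beyond the scatter). Set beside the earlier step, the change carried over from one core to the other in direction and, within the scatter, in size: the same change on two cores in this assay, an 8.8-fold higher number (0.94 log units; beyond the scatter) from compound 1 to compound 2 and a 4.7-fold higher number (0.67 log units; beyond the scatter) from compound 3 to compound 4, 1.9-fold (0.27 log units) apart, within the scatter of two such steps. Within the data shown here, this rests on only two pairs, so it does not show why the change weakens inhibition or that it would do the same on a further core.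

The compounds shown leave open how a plain methyl or a longer chain on the carbonyl carbon would compare with these two groups. Also open, going by these compounds, is whether the step would hold on a core carrying an amine.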